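Phenyl in place of methyl on the shared core

The source may hold more compounds than are shown below. What is called first, only, known or untested is meant among the compounds shown, and "the series" means these compounds.

In a functional assay on L02 cells (Homo sapiens) for inhibition, read by Griess assay, with stated times of 1 h and 24 h (a higher number here means a weaker inhibitor, a lower number a stronger inhibitor), compound 1 `COc1ccc(Nc2nc(/C=C/c3ccccc3)nc3ccsc23)cc1` gives only the limit > 1000000 nM.
Compound 2 `Clc1ccccc1CNc1nc(/C=C/c2ccccc2)nc2ccsc12` gives only the limit > 1000000 nM in this assay.
Compound 3 `COc1cc(/C=C/c2nc(N(C)C)c3sccc3n2)cc(OC)c1OC` gives only the limit > 1000000 nM in this assay.

Compound 3 therefore stands at a limit rather than a number, the same limit at which every value shown sits (the limit of > 1000000 nM in this assay, at which 3 of the 3 values shown sit). Compound 4 `COc1cc(/C=C/c2nc(N(C)c3ccccc3)c3sccc3n2)cc(OC)c1OC` differs from compound 3 by phenyl in place of methyl on a nitrogen on an aromatic ring. Within the data shown here, the only measured step, a step that the two limits leave unreadable from compound 1 to compound 2, runs between two limits and cannot be read, and it concerns a different group on a nitrogen, so it gives no size to carry over. With all shown values at the limit, no step beyond the scatter is expected; the estimated step of a number no higher from compound 3 to compound 4 (the limit leaves the size open) is expected to be close to none. Compound 4 is estimated at 1000000 nM, between 300000 nM and 3000000 nM, most likely reported again only as a limit.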

Compound 4, half-maximal inhibitory concentration: 767000 nM
For compound 4 the middle estimate is 1.3-fold (0.12 log units) above the measured one, within the range that was stated.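

On the nitrogen on an aromatic ring, phenyl in place of methyl gives an at least 1.3-fold lower number from compound 3 to compound 4 (0.11 log units; that floor lies within the scatter). Compound 3 is held only by a limit, so the true step may be larger, but this floor alone shows no change beyond the scatter. Compound 4 alone reads as a number, while the others stay at a limit: the limit of > 1000000 nM in this assay, at which 3 of the 4 values shown sit.

As far as these compounds go, what a carboxylic acid or an amine on the added phenyl would do in this assay stays open. So does the effect of a longer chain, such as butyl, in its place.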